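A few compounds are considered here, and "the series" means these few. Any claim that something is new, unique, unknown or untested is made for them only; others in the source may bear on it.

Measured so far:
compound 1 `O=C(CCl)N1N=C(c2cc3ccccc3oc2=O)CC1c1ccccc1`, 2980 nM
compound 2 `CCCNCC(=O)N1N=C(c2cc3ccccc3oc2=O)CC1c1ccccc1`, 7270 nM

In a functional assay on PC-3 cells (Homo sapiens) for cytotoxicity, read by MTT assay, with a stated time of 48 h (a lower number here means a stronger inhibitor, a higher number a weaker inhibitor), compound 1 gives 2980 nM. In this assay, among the compounds with values here, compound 2 gives 7270 nM, the highest of the two numbers, and the only step known is a 2.4-fold higher number from compound 1 to compound 2 (0.39 log units; beyond the scatter). Compound 3 `CC1CCCCN1CC(=O)N1N=C(c2cc3ccccc3oc2=O)CC1c1ccccc1` is not yet measured; it differs from compound 2 by 2-methylpiperidin-1-yl in place of propylamino on a saturated chain carbon bound to a carbonyl carbon. Within the data shown here, no measured step shows what exchanging one amine for another at this place does; the one step known runs from a chloro group to an amine and does not read across directly. With so little to go on, the change from compound 2 to compound 3 is expected to stay near the scatter, with a wide range around it, as a 1.2-fold lower number from compound 2 to compound 3 (0.08 log units; within the scatter). Compound 3 is therefore estimated at 6000 nM in this assay, between 2500 nM and 15000 nM.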

Compound 3, half-maximal inhibitory concentration: 36300 nM
Compound 3: middle estimate off by 6.1-fold (0.78 log units), on the low side; measured number above the stated range.
By their numbers in this assay, from the lowest: compound 1; then compound 2; then compound 3.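

Within this assay, exchanging one amine for another at this place is not a neutral change: 2-methylpiperidin-1-yl in place of propylamino gives a 5.0-fold higher number from compound 2 to compound 3 (0.70 log units; beyond the scatter) and lies beyond the scatter. Set against the chloro group, the ring amine gives a 12-fold higher number from compound 1 to compound 3 (1.09 log units; beyond the scatter), so among these three compounds both amines carry higher numbers than chloro, and the identity of the amine matters as well as its presence. No measurement offered here accounts for this rise.

Compound 3 differs from compound 2 in its ring, its methyl group and its count of hydrogen-bond donors all at once, so these features cannot be told apart. The compounds shown leave open where an unsubstituted piperidin-1-yl, a morpholine or an open-chain diethylamino group would stand at this place.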